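A few compounds are considered here, and "the series" means these few. Any claim that something is new, unique, unknown or untested is made for them only; others in the source may bear on it.

Measured so far:
compound 1 `CCO/C(O)=C1\C(COCCn2nncc2C(N)=O)=NC(C)=C(C(=O)OC)C1c1ccccc1Cl` — 100 nM
compound 2 `CCO/C(O)=C1\C(COCCN2CC(=O)NC2=O)=NC(C)=C(C(=O)OC)C1c1ccccc1Cl` — 20 nM
compound 3 `CCO/C(O)=C1\C(COCCn2nncc2C(N)=O)=NC(C)=C(C(=O)OC)C1c1cccc(Cl)c1Cl` — 15.9 nM

In a functional assay (aorta) with Rattus norvegicus as the target (on this read-out higher numbers stand for weaker inhibition and lower numbers for stronger inhibition), compound 1 gives 100 nM, compound 2 gives 20 nM and compound 3 gives 15.9 nM. Two single changes branch from compound 1. The first, (2,4-dioxoimidazolidin-1-yl in place of 5-carbamoyl-1H-1,2,3-triazol-1-yl on a saturated chain carbon, two bonds along the chain from an oxygen on a saturated carbon), gives a 5.0-fold lower number from compound 1 to compound 2 (0.70 log units; beyond the scatter). The second, (chloro in place of hydrogen on an aromatic carbon), gives a 6.3-fold lower number from compound 1 to compound 3 (0.80 log units; beyond the scatter). Compound 2 and compound 3 lie within the scatter of each other, so no order between them is claimed.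

Compound 4 `CCO/C(O)=C1\C(COCCN2CC(=O)NC2=O)=NC(C)=C(C(=O)OC)C1c1cccc(Cl)c1Cl` is not yet measured in this assay. It differs from compound 3 by 2,4-dioxoimidazolidin-1-yl in place of 5-carbamoyl-1H-1,2,3-triazol-1-yl on a saturated chain carbon, two bonds along the chain from an oxygen on a saturated carbon, which is the same change as that from compound 1 to compound 2; the place is described in the same words in both cases, so the change is the same and not merely of the same kind. The two cores differ by chloro in place of hydrogen on an aromatic carbon. If the change transfers unchanged onto the core of compound 3, a step of about a 4.0-fold lower number from compound 3 to compound 4 (0.60 log units; beyond the scatter) is expected, because the same change gave a 5.0-fold lower number from compound 1 to compound 2 (0.70 log units; beyond the scatter). Compound 4 is therefore estimated at 4 nM, with a range from 1.5 nM to 12 nM. The estimate rests on one earlier occurrence of the change only.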

Compound 4, half-maximal inhibitory concentration: 3.16 nM
Estimate against measurement, compound 4: 1.3-fold (0.10 log units) above; the range from low to high includes it.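

In this assay, 2,4-dioxoimidazolidin-1-yl in place of 5-carbamoyl-1H-1,2,3-triazol-1-yl gives a 5.0-fold lower number from compound 3 to compound 4 (0.70 log units; beyond the scatter), and this step repeats the earlier one on the chloro-bearing core: the same change on two cores in this assay, a 5.0-fold lower number (0.70 log units; beyond the scatter) from compound 1 to compound 2 and a 5.0-fold lower number (0.70 log units; beyond the scatter) from compound 3 to compound 4, 1.0-fold (0.00 log units) apart, within the scatter of two such steps. Read the other way round, chloro in place of hydrogen on an aromatic carbon gives a 6.3-fold lower number from compound 2 to compound 4 (0.80 log units; beyond the scatter), and this step also repeats: the same change on two cores in this assay, a 6.3-fold lower number (0.80 log units; beyond the scatter) from compound 1 to compound 3 and a 6.3-fold lower number (0.80 log units; beyond the scatter) from compound 2 to compound 4, 1.0-fold (0.00 log units) apart, within the scatter of two such steps. On these four compounds the two changes therefore carry over from one core to the other without a visible loss, but this is a single pair of cores in a single read-out, so it shows neither why the steps hold nor that they would hold on any other core.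

Still open, going by these compounds, is whether the same step would appear with an amine or a carboxylic acid in place of 2,4-dioxoimidazolidin-1-yl, or with a longer chain in place of the ethoxy link. Also open, on these data alone, is whether fluoro or methyl in place of the added chloro would carry over in the same way.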